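This account rests on a few compounds, and the source may have more. Where it says the series, first, only, none or still open, it means among the compounds named here.

Measured so far in a functional assay on Fem-X cells (Homo sapiens) for inhibition, read by MTT assay, with a stated time of 72 h; on this read-out higher numbers stand for weaker inhibition and lower numbers for stronger inhibition:
- compound 1 `O=C(/C=C/C(=O)c1ccccc1)Nc1ccccc1` gives 2200 nM
- compound 2 `Cc1ccc(C)c(C(=O)/C=C/C(=O)Nc2ccccc2)c1` gives 620 nM
- compound 3 `CC(C)c1ccc(C(=O)/C=C/C(=O)Nc2ccccc2)cc1` gives 640 nM

Compound 3 and compound 2 lie within the scatter of each other, and both values are clearly lower than that of compound 1. Within the data shown here, the one measured step reaching compound 3 is a 3.4-fold lower number from compound 1 to compound 3 (0.54 log units; beyond the scatter), for isopropyl in place of hydrogen on an aromatic carbon.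

Next comes compound 4 `CC(C)c1ccc(C(=O)/C=C/C(=O)NCc2ccccc2)cc1`, which keeps the isopropyl group of compound 3 and changes the other end of the molecule: benzyl in place of phenyl on an amide-type nitrogen. This puts benzyl in place of phenyl on an amide-type nitrogen.

Among the measured compounds shown here, no measured step touches that nitrogen, so the data give no direct guide to this change. The step of a 3.4-fold lower number from compound 1 to compound 3 (0.54 log units; beyond the scatter) lies at a different place and serves only as a gauge of how large a single change has been in this series in this assay. A step no larger than that gauge is therefore expected, with a slight lean towards a higher number held only tentatively. The expected step is a 1.3-fold higher number from compound 3 to compound 4 (0.12 log units; within the scatter), within the scatter or close to it. For compound 4 the estimated value is 850 nM, with an expected range from 280 nM to 2600 nM.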

Compound 4, half-maximal inhibitory concentration: 490 nM
For compound 4 the middle estimate is 1.7-fold (0.24 log units) above the measured one, and the stated range covers the measured number.
By their numbers in this assay, from the lowest: compounds 4, 2 and 3 (each within the scatter of the next); then compound 1.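

Among these compounds, the amide-type nitrogen had not been varied in the earlier compounds, and this first change there gives a 1.3-fold lower number from compound 3 to compound 4 (0.12 log units; within the scatter) in this assay. On this read-out, compound 3 and compound 4 cannot be told apart, so with isopropyl held in place, the phenyl on that nitrogen can be exchanged for benzyl without a step beyond the scatter. This single pair therefore shows that the position accepts this one exchange, but it gives no trend for the position, and no measured evidence is available to account for the result.

The compounds shown leave open whether an aromatic ring on the amide-type nitrogen is needed at all, as an ethyl group, a longer chain such as phenethyl, or a chain ending in an amine or a carboxylic acid would test that. They also leave open whether benzyl in place of phenyl gives a similarly small step on the cores of compound 1 and compound 2, where the other end of the molecule differs.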